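A few compounds are considered here, and "the series" means these few. Any claim that something is new, unique, unknown or untested is made for them only; others in the source may bear on it.

Compound 1 `Cc1ccc(-c2cs/c(=N/NC(=O)CSc3nnnn3-c3ccccc3)n2-c2ccccc2)cc1` gives 55.1% in a functional assay on C6 cells (Rattus norvegicus) for cytotoxicity, read by MTT assay, with a stated time of 24 h, tested at 12 ug/mL (on this read-out lower numbers stand for a stronger effect and higher numbers for a weaker effect at the one concentration tested), the lowest of the three numbers recorded, so the strongest effect in this small set. Compound 2 `Cc1ccc(-c2cs/c(=N/NC(=O)CSc3nncn3C)n2-c2ccccc2)cc1` gives 72% and compound 3 `Cc1ccc(-c2cs/c(=N/NC(=O)CSc3ncccn3)n2-c2ccccc2)cc1` gives 83%. The measured steps of a number 16.9 percentage points higher from compound 1 to compound 2 (beyond the scatter), a number 27.9 percentage points higher from compound 1 to compound 3 (beyond the scatter) and a number 11 percentage points higher from compound 2 to compound 3 (beyond the scatter) all exchange the group carried on the sulfur and leave the rest of the core untouched. Compound 4 `N#Cc1ccc(-c2cs/c(=N/NC(=O)CSc3nnnn3-c3ccccc3)n2-c2ccccc2)cc1` differs from compound 1 at a different place: cyano in place of methyl on an aromatic carbon. For the measured compounds named here, no measured step varies this position, so none of the three steps bears on it directly, and the sulfur-bound group of compound 1 is kept. The expectation is therefore no change beyond the scatter. Compound 4 is estimated at 55%, within 40% to 72%, a step of a number 0.1 percentage points lower from compound 1 to compound 4 (within the scatter) expected.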

Compound 4, a percentage reported as activity, at one concentration (the size of the read-out at that concentration, not a potency): 74.1%
Compound 4: middle estimate off by 19.1 percentage points, on the low side; the measured number lies above the stated range.
By their numbers in this assay, from the lowest: compound 1; then compounds 2, 4 and 3 (each within the scatter of the next, the first and the last beyond it).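

On the 4-methylphenyl group, the change to 4-cyanophenyl with the sulfur-bound group kept gives a number 19 percentage points higher from compound 1 to compound 4 (beyond the scatter) in this assay, a weaker effect at the one concentration tested. This position therefore moves the read-out beyond the scatter, as the exchanges on the sulfur do. Nothing available explains this step.

Open, from the compounds shown here alone, is how other groups at this place, such as an amine, a methoxy group or a chlorine atom, would read. Also open, going by these compounds, is whether the cyano step holds with the 4-methyl-4H-1,2,4-triazol-3-yl or pyrimidin-2-yl group on the sulfur.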